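Swapping the ring-nitrogen substituent of compound 3

The source may report more compounds than this note shows. Statements on the series, on what has been measured and on what is new or still open speak of the compounds shown alone.

Three compounds share a core and differ only in the group carried on the amine nitrogen in the ring. Compound 1 `Cc1ccccc1CN1CCc2c(sc(NC(=O)c3ccccc3Cl)c2C(N)=O)C1` gives in a functional assay on HL-60 cells (Homo sapiens) for antiproliferative activity, with a stated time of 24 h (a higher number here means a weaker inhibitor, a lower number a stronger inhibitor), a value that is a limit of the assay, > 50000 nM. Compound 2 `NC(=O)c1c(NC(=O)c2ccccc2Cl)sc2c1CCN(C(=O)Nc1ccccc1Cl)C2` gives 12500 nM. Compound 3 `COc1ccccc1NC(=S)N1CCc2c(sc(NC(=O)c3ccccc3Cl)c2C(N)=O)C1` gives 40900 nM, the highest of the two actual numbers; the nearest is compound 2, reached by a 3.3-fold higher number from compound 2 to compound 3 (0.51 log units; beyond the scatter).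

The step to compound 4 `NC(=O)c1c(NC(=O)c2ccccc2Cl)sc2c1CCN(C(=O)Nc1c(Cl)cccc1Cl)C2` changes that same position: a group of 11 heavy atoms (7 carbon, 1 nitrogen, 1 oxygen, 2 chlorine; one six-membered aromatic ring of carbon only) in place of a group of 11 heavy atoms (8 carbon, 1 nitrogen, 1 oxygen, 1 sulfur; one six-membered aromatic ring of carbon only), on an amine nitrogen in a ring. Going by the values given here, the new group resembles the one in compound 2 more than the one in compound 3, since both carry a carbamoyl linker to a chlorinated phenyl ring. Among the compounds with values here, the measured step that bears on this is the one between compound 2 and compound 3, where the number rose by a 3.3-fold higher number from compound 2 to compound 3 (0.51 log units; beyond the scatter). Reversing that kind of change, with an extra chlorine on the ring, is expected to lower the number in this assay by a modest step, a 3.4-fold lower number from compound 3 to compound 4 (0.53 log units; beyond the scatter). Compound 4 is therefore estimated at 12000 nM, with a plausible range from 4000 nM to 40000 nM.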

Compound 4, half-maximal inhibitory concentration: 17700 nM
Estimate against measurement, compound 4: 1.5-fold (0.17 log units) below; the measured number falls inside the stated range.
By their numbers in this assay, from the lowest: compounds 2 and 4 (each within the scatter of the next); then compound 3. At a limit, above all of these: compound 1.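

Exchanging the sulfur-bearing group of compound 3 for (2,6-dichlorophenyl)carbamoyl on the amine nitrogen in the ring gives a 2.3-fold lower number from compound 3 to compound 4 (0.36 log units; beyond the scatter) in this assay, so a second carbamoyl compound now falls on the lower side of compound 3. The added chlorine does not separate the two carbamoyl compounds, with chloro in place of hydrogen on an aromatic carbon giving a 1.4-fold higher number from compound 2 to compound 4 (0.15 log units; within the scatter), so compounds 2 and 4 cannot be put in order and this position tolerates that extra chlorine in this assay. Compound 1 stands at a limit, so the step to the carbamoyl group, an at least 2.8-fold lower number from compound 1 to compound 4 (0.45 log units; beyond the scatter), gives only a floor for the true size of the change: the limit of > 50000 nM in this assay, at which 1 of the 4 values shown sits.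

Compounds 3 and 4 differ in both the linking group and the ring substituents, so these shown steps cannot say how much of their gap belongs to each; a (2-methoxyphenyl)carbamoyl group, with oxygen in place of the sulfur of compound 3, would separate the two. On these data alone, it also stays open whether the chlorines contribute at all, which an unsubstituted phenylcarbamoyl group would help to settle.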